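This account rests on a few compounds, and the source may have more. Where it says the series, first, only, none or still open, it means among the compounds named here.

Compound 1 `COc1ccccc1/C=C1\CN(CC(=O)O)c2c(C)cccc2C1=O` gives 4.72% in an assay on HL-60 cells for inhibition of glutathione S-transferase P (Homo sapiens), read by spectrophotometry, tested at 20 uM (on this read-out lower numbers stand for less inhibition and higher numbers for more inhibition at the one concentration tested (going by the name of the read-out)), the lowest of the three numbers measured, though its neighbours lie close by. Compound 2 `COc1ccc(OC)c(/C=C2\CN(CC(=O)O)c3c(C)cccc3C2=O)c1` gives 5.44% and compound 3 `COc1ccc(/C=C2\CN(CC(=O)O)c3c(C)cccc3C2=O)c(OC)c1` gives 11.7%. Both measured steps add a methoxy group on an aromatic carbon of the pendant ring: a number 0.7 percentage points higher from compound 1 to compound 2 (within the scatter) and a number 7 percentage points higher from compound 1 to compound 3 (within the scatter), each within the scatter of the measurement.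

Compound 4 `Cc1cccc2c1N(CC(=O)O)C/C(=C\c1ccccc1Cl)C2=O` has not yet been measured. It differs from compound 1 in one place: chloro in place of methoxy on an aromatic carbon, so that the 2-methoxyphenyl of compound 1 becomes the 2-chlorophenyl of compound 4. Within the data shown here, no measured step exchanges one substituent for another on that ring; the two steps at hand only add a methoxy group and leave the number within the scatter. The one relevant lesson is that changes on this ring have so far moved the read-out little. Compound 4 is therefore expected to give 6%, within 0% to 16%. The expected step of a number 1.3 percentage points higher from compound 1 to compound 4 (within the scatter) is one that stays within the scatter.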

Compound 4, a percentage reported as inhibition, at one concentration (the size of the read-out at that concentration, not a potency): 51.9%
The estimate for compound 4 lay 45.9 percentage points below the measured number; measured number above the stated range.
By their numbers in this assay, from the lowest: compounds 1, 2 and 3 (each within the scatter of the next); then compound 4.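

In this assay, replacing methoxy with chloro at this place, ortho to a large group, gives a number 47.2 percentage points higher from compound 1 to compound 4 (beyond the scatter), the only listed step beyond the scatter. The earlier steps shown here added a second methoxy while the 2-methoxyphenyl stayed in place, so they did not test the group at this position itself. This exchange shows that the read-out is not indifferent to every change on this aromatic ring, and that the group at this place can matter greatly. Nothing measured here speaks to the reason for this step.

The compounds shown leave open whether the gain belongs to chloro in particular or follows from the loss of methoxy; a bromo, a methyl or plain hydrogen at this place would help separate the two. As far as these compounds go, it also remains open whether chloro would have the same effect alongside a second methoxy on the ring.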